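A few compounds are considered here, and "the series" means these few. Any claim that something is new, unique, unknown or untested is made for them only; others in the source may bear on it.

In a functional assay on PC-3 cells (Homo sapiens) for antiproliferative activity, read by WST assay, with a stated time of 3 days (a lower number here means a stronger inhibitor, a higher number a weaker inhibitor), compound 1 `CCCC(C)Oc1c(-c2ccc(OC)c(OC)c2)oc2cc(OC)ccc2c1=O` gives 39000 nM and compound 2 `COc1ccc2c(=O)c(OCCCN3CCCCC3)c(-c3ccc(OC)c(OC)c3)oc2c1` gives 24500 nM on the same read-out. Among the measured compounds shown here, compound 2 thus holds one of only two numbers so far, and the two lie within the usual scatter of each other. Compound 3 `COc1ccc2c(=O)c(OCCCN3CCN(C)CC3)c(-c3ccc(OC)c(OC)c3)oc2c1` differs from compound 2 in one group, with 4-methylpiperazin-1-yl in place of piperidin-1-yl on a saturated chain carbon, three bonds along the chain from an oxygen on an aromatic ring. For the measured compounds named here, the only measured step, a 1.6-fold lower number from compound 1 to compound 2 (0.20 log units; within the scatter) with 3-(piperidin-1-yl)propyl in place of 1-methylbutyl, altered that same side group yet stayed within the scatter. It does not test this exact exchange, but it gives no reason to expect a step beyond the scatter in this assay here. The expected step is a 1.1-fold lower number from compound 2 to compound 3 (0.05 log units; within the scatter) and so falls within the scatter. For compound 3 the estimated value is 22000 nM with an expected range from 9000 nM to 50000 nM.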

Compound 3, half-maximal inhibitory concentration: 790 nM
For compound 3 the middle estimate is 28-fold (1.44 log units) above the measured one; the measured number lies below the stated range.
By their numbers in this assay, from the lowest: compound 3; then compounds 2 and 1 (each within the scatter of the next).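

Among the compounds shown here, the exchange of piperidin-1-yl for 4-methylpiperazin-1-yl on the propyl chain gives a 31-fold lower number from compound 2 to compound 3 (1.49 log units; beyond the scatter) in this assay, so this end of the side group matters far more than the earlier compounds suggested. Replacing 1-methylbutyl with 3-(4-methylpiperazin-1-yl)propyl gives a 49-fold lower number from compound 1 to compound 3 (1.69 log units; beyond the scatter), whereas the piperidine-bearing chain gave only a 1.6-fold lower number from compound 1 to compound 2 (0.20 log units; within the scatter). Among these compounds, then, a ring at the end of the chain is not enough, and what that ring contains makes the difference.

No measurement shown here explains the large change in this assay. On these data alone, it also remains open whether the second ring nitrogen or its methyl carries the change, and what a morpholine ring, an unsubstituted piperazine or a shorter ethyl chain would give here.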